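The source may hold more compounds than are shown below. What is called first, only, known or untested is meant among the compounds shown, and "the series" means these compounds.

Going by the values given here, in an assay on cells with melanin-concentrating hormone receptor 1 (Homo sapiens) as the target, read by radioligand binding (on this read-out lower numbers stand for stronger inhibition and higher numbers for weaker inhibition), compound 3 `Nc1ccc2cccc(OCCC(F)(F)F)c2n1` gives 722 nM, one of only two plain numbers in the set, the other being compound 2 `COCC(C)Oc1cccc2ccc(N)nc12` at 606 nM, and the step of a 1.2-fold higher number from compound 2 to compound 3 (0.08 log units; within the scatter) lies within the scatter. Compound 1 `Nc1ccc2cccc(OC3CCC3)c2n1` gives > 2000 nM, which is a limit of the assay rather than a number. Compound 4 `CCCOc1cccc2ccc(N)nc12` differs from compound 3 by methyl in place of trifluoromethyl on a saturated chain carbon, two bonds along the chain from an oxygen on an aromatic ring. Among the compounds with values here, no measured step touches this position directly; the steps of an at least 2.7-fold lower number from compound 1 to compound 3 (0.44 log units; beyond the scatter) and an at least 3.3-fold lower number from compound 1 to compound 2 (0.51 log units; beyond the scatter) each swap the whole group on the oxygen, and both rest on the limit (the limit of > 2000 nM in this assay, at which 1 of the 3 values shown sits). Compound 4 is therefore expected to show no step beyond the scatter, a 1.2-fold higher number from compound 3 to compound 4 (0.10 log units; within the scatter), with an estimated value of 900 nM and a range from 300 nM to 2500 nM.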

Compound 4, half-maximal inhibitory concentration: 1100 nM
For compound 4 the middle estimate is 1.2-fold (0.09 log units) below the measured one; the range from low to high includes it.
By their numbers in this assay, from the lowest: compounds 2, 3 and 4 (each within the scatter of the next). At a limit, above all of these: compound 1.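

In this assay, the change at this position alone, from trifluoromethyl to methyl, gives a 1.5-fold higher number from compound 3 to compound 4 (0.18 log units; within the scatter), so removing the fluorine atoms leaves no readable difference. The propyl group also stays level with the branched ether group, with a 1.8-fold higher number from compound 2 to compound 4 (0.26 log units; within the scatter). Against the cyclobutyl group, the step is an at least 1.8-fold lower number from compound 1 to compound 4 (0.25 log units; that floor lies within the scatter); it rests on a limit and, unlike the earlier steps from that compound, does not establish a difference. On these data alone, whether an amine, a carboxylic acid or a longer chain at this position would shift the number beyond the scatter remains open.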